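A few compounds are considered here, and "the series" means these few. Any claim that something is new, unique, unknown or untested is made for them only; others in the source may bear on it.

Three compounds set the scene in a functional assay on MCF7 cells (Homo sapiens) for inhibition, read by MTT assay, with a stated time of 48 h; a higher number here means a weaker inhibitor, a lower number a stronger inhibitor. Compound 1 `N#Cc1c(-c2ccc(Cl)cc2)nc2c(c(-c3ccccc3)nn2-c2ccccc2)c1-c1ccc(N2CCCCC2)cc1` gives 10600 nM, and compound 3 `COc1ccc(-c2nc3c(c(-c4ccccc4)nn3-c3ccccc3)c(-c3ccc(N4CCN(C)CC4)cc3)c2C#N)cc1` gives 2650 nM. Compound 2 `Brc1ccc(-c2ccnc3c2c(-c2ccccc2)nn3-c2ccccc2)cc1`, a smaller molecule than either, gives 13300 nM, the highest of the three numbers: its number sits within the scatter of compound 1, so no order can be read between those two, while the number of compound 3 lies lower by a gap that is beyond the scatter.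

Compound 4 `Fc1ccc(-c2ccnc3c2c(-c2ccccc2)nn3-c2ccccc2)cc1` has not yet been measured. It keeps the whole framework of compound 2 and differs in one spot only: fluoro in place of bromo on an aromatic carbon. Within the data shown here, no measured pair in this set isolates such a swap, so there is no step to lean on. A single halogen exchanged for another at the same position is expected to move the number little, and any shift would more plausibly be upward than downward. Compound 4 is therefore expected to give 16000 nM, within a range from 6000 nM to 40000 nM. That estimate corresponds to a step of a 1.2-fold higher number from compound 2 to compound 4 (0.08 log units; within the scatter), which is expected to fall inside the scatter.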

Compound 4, half-maximal inhibitory concentration: 1570 nM
Compound 4: middle estimate off by 10-fold (1.01 log units), on the high side; measured number outside the range, below it.
By their numbers in this assay, from the lowest: compounds 4 and 3 (each within the scatter of the next); then compounds 1 and 2 (each within the scatter of the next).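

In this assay, exchanging one halogen for another, 4-bromophenyl to 4-fluorophenyl, produces an 8.5-fold lower number from compound 2 to compound 4 (0.93 log units; beyond the scatter), a step beyond the scatter. This shows that the aromatic carbon para to a large group is not indifferent to which halogen it carries, even though the change replaces one heavy atom with one heavy atom and leaves the rest of the framework untouched. The earlier compounds could not show this, as no measured pair isolated a change at this spot, and nothing available explains the size of the step.

On these data alone, with only bromo and fluoro compared here, it remains open how a methyl group or an amine at the same position would read. As far as these compounds go, it also remains open whether the bromo to fluoro step would hold on a framework carrying a nitrile.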